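Cyanoguanidine side-chain series, whole-animal stomach read-out

The source may hold more compounds than are shown below. What is called first, only, known or untested is meant among the compounds shown, and "the series" means these compounds.

Measured compounds:
compound 1 `CCC/N=C(/NC#N)NCCCCn1nc(-c2ccccc2)ccc1=O` gives > 100 mg/kg, a limit of the assay.
compound 2 `CCC/N=C(/NC#N)NCCCn1nc(-c2ccccc2)ccc1=O` gives 100 mg/kg.
compound 3 `CC/N=C(/NC#N)NCCCCn1nc(-c2ccccc2)c(C)cc1=O` gives > 100 mg/kg, a limit of the assay.

In a functional assay on the whole organism (stomach) with Rattus norvegicus as the target (on this read-out higher numbers stand for an effect only at larger amounts of compound and lower numbers for an effect already at smaller amounts), compound 1 sits only at a limit; the same holds for compound 3, as the limit of > 100 mg/kg in this assay, at which 2 of the 3 values shown sit, states. For the measured compounds named here, compound 2 is the one compound with a number, and that number coincides with the limit itself, so no measured step between these compounds can be stated.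

Compound 4 `N#CNC(=N)NCCCCn1nc(-c2ccccc2)ccc1=O` differs from compound 1 by a group of 5 heavy atoms (2 carbon, 3 nitrogen; no ring) in place of a group of 8 heavy atoms (5 carbon, 3 nitrogen; no ring), on an amine nitrogen. Going by the values given here, no measured step covers a change of this kind here. Given that compound 1 shows > 100 mg/kg, compound 4 is expected near the limit as well, with a number no higher from compound 1 to compound 4 (the limit leaves the size open) expected to be no step beyond the scatter. The estimate for compound 4 is 100 mg/kg, between 50 mg/kg and 200 mg/kg.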

Compound 4, dose for half-maximal effect: 77.2 mg/kg
Estimate against measurement, compound 4: 1.3-fold (0.11 log units) above; the measured number falls inside the stated range.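

On the amine nitrogen, the group of 5 heavy atoms in place of the group of 8 heavy atoms gives, in this assay, an at least 1.2-fold lower number from compound 1 to compound 4 (0.11 log units; that floor lies within the scatter). Compound 4 gives a readable number, 77.2 mg/kg, so an effect can still be measured with the smaller group at this position. The true size of the step remains unknown because compound 1 sits only at a limit: the limit of > 100 mg/kg in this assay, at which 2 of the 4 values shown sit.

Going by these compounds, whether a benzyl group or a carboxylic acid-bearing chain on this nitrogen would move the number beyond the scatter remains open. Also open, on these data alone, is whether the same change would act alike on the shared core with a shorter linking chain.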